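Trading a pyridine for a cyclopropane on the side chain

The source may hold more compounds than are shown below. What is called first, only, known or untested is meant among the compounds shown, and "the series" means these compounds.

Of the compounds shown here, three sharing one core have been tested in a functional assay on HEK293 cells for agonist activity at G-protein coupled receptor 39 (Mus musculus), read by inositol phosphate accumulation; on this read-out lower numbers stand for an effect already at smaller amounts and higher numbers for an effect only at larger amounts of compound. Compound 1 `COCCNc1nc(NCC2CC2)cc(-c2ccccn2)n1` gives 10000 nM. Compound 2 `CNc1nc(NCC(C)(C)C)cc(-c2ccccn2)n1` gives 365 nM, and compound 3 `CNc1nc(NCc2ccncc2)cc(-c2ccccn2)n1` gives 304 nM. Compound 3 holds the lowest of the three numbers, yet its gap to compound 2 is within the scatter, so the two cannot be ranked; only the gap to compound 1 is beyond it. Among the compounds with values here, the single one-place step measured so far, a 1.2-fold lower number from compound 2 to compound 3 (0.08 log units; within the scatter), shows that swapping one group on the saturated chain carbon bound to the ring nitrogen barely moved the read-out.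

Compound 4 `CNc1nc(NCC2CC2)cc(-c2ccccn2)n1` is not yet measured. It differs from compound 3 in one place: cyclopropyl in place of pyridin-4-yl on a saturated chain carbon bound to a nitrogen on an aromatic ring. Compound 1 also carries this cyclopropylmethyl chain, but with a different group on the other ring nitrogen, so its high number cannot be attributed to the chain alone. Given the flat step a 1.2-fold lower number from compound 2 to compound 3 (0.08 log units; within the scatter), the change in this assay is expected to be small, a 1.6-fold higher number from compound 3 to compound 4 (0.22 log units; within the scatter). Compound 4 is estimated at 500 nM, with a range from 150 nM to 2000 nM.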

Compound 4, half-maximal effective concentration: 115 nM
The estimate for compound 4 lay 4.3-fold (0.64 log units) above the measured number; the measured number lies below the stated range.
By their numbers in this assay, from the lowest: compound 4; then compounds 3 and 2 (each within the scatter of the next); then compound 1.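

In this assay, within the data shown here, the side-chain position proves less flat than the earlier compounds suggested: there is a 2.6-fold lower number from compound 3 to compound 4 (0.42 log units; beyond the scatter) with cyclopropyl replacing pyridin-4-yl, and a 3.2-fold lower number from compound 2 to compound 4 (0.50 log units; beyond the scatter) with cyclopropyl replacing tert-butyl. Compound 2 and compound 3 could not be ranked, yet compound 4 stands apart from both, so this position can respond to the group it carries. Compound 1 shares the cyclopropylmethyl chain, and there is an 87-fold lower number from compound 1 to compound 4 (1.94 log units; beyond the scatter) with hydrogen in place of methoxymethyl on the chain at the other nitrogen, so the high number of compound 1 does not come from the cyclopropylmethyl chain.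

Nothing available explains why either change moves the read-out. On these data alone, it remains open whether a cyclobutyl or isopropyl group on this chain carbon would match cyclopropyl, and whether an ethyl group on the other nitrogen would keep the number of compound 4.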